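Compound 4: a Second Chloro Added to Compound 3

The source may hold more compounds than are shown below. What is called first, only, known or untested is meant among the compounds shown, and "the series" means these compounds.

Compound 3 `CCOC(=O)c1c(-c2ccc(Cl)cc2)cc(-c2ccccc2)nc1Nc1ccc(Cl)cc1` stands in a functional assay on the whole organism (strain Wister albino) for inhibition, with Rattus norvegicus as the target, read by paw edema, with stated times of 1 h and 24 h, at a dose of 50 mg/kg by the intraperitoneal route (on this read-out lower numbers stand for less inhibition and higher numbers for more inhibition at the one dose given (going by the name of the read-out)), at 32.9%, the smallest of the three numbers, within the scatter of compound 2 yet beyond it against compound 1. Compound 2 `CCOC(=O)c1c(-c2ccc(Cl)c(Cl)c2)cc(-c2ccccc2)nc1Nc1ccc(C)cc1` gives 40.8%, and compound 1 `CCOC(=O)c1c(-c2ccc(Cl)c(Cl)c2)cc(-c2ccccc2)nc1N1CCCCC1` gives 48.9%. Among the compounds with values here, the only single-point step measured is a number 8.1 percentage points lower from compound 1 to compound 2 (within the scatter), a change of a different kind. Compound 4 `CCOC(=O)c1c(-c2ccc(Cl)c(Cl)c2)cc(-c2ccccc2)nc1Nc1ccc(Cl)cc1` differs from compound 3 by chloro in place of hydrogen on an aromatic carbon. Within the data shown here, no measured step involves this change; compound 2 and compound 3 differ in two places, and their values show only that they lie within the scatter of each other. The step is therefore expected to be a number 3.1 percentage points higher from compound 3 to compound 4 (within the scatter), nothing beyond the scatter. Compound 4 is estimated at 36%, with a range from 22% to 50%.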

Compound 4, a percentage reported as inhibition, in the whole organism at one dose (the size of the read-out at that dose, not a potency): 52.7%
Beside the measured number, compound 4's estimate is 16.7 percentage points below it; the measured number lies above the stated range.
By their numbers in this assay, from the lowest: compounds 3, 2, 1 and 4 (each within the scatter of the next, the first and the last beyond it).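

In this assay the change from 4-chlorophenyl to 3,4-dichlorophenyl gives the first step read at this position, a number 19.8 percentage points higher from compound 3 to compound 4 (beyond the scatter) and so a chloro added ortho to a chloro group shifts this read-out. With the 3,4-dichlorophenyl kept, chloro in place of methyl gives a number 11.9 percentage points higher from compound 2 to compound 4 (beyond the scatter) whereas (4-chlorophenyl)amino in place of piperidin-1-yl gives a number 3.8 percentage points higher from compound 1 to compound 4 (within the scatter) and that step stays within the scatter. No evidence at hand accounts for these steps.

The compounds shown leave open whether bromo or methoxy at this position would give a step of similar size. They also leave open whether the chloro step would hold with piperidin-1-yl in place of the (4-chlorophenyl)amino group.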